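Benzothiophene in place of trifluoromethylphenyl: cytotoxicity outlook

The compounds below may be only part of what the source reports. "The series", "measured", "known", "first", "only" and "open" are said of these compounds alone.

Measured compounds:
compound 1, `O=C(NC(=S)n1ccc2c(OCCCCCOc3ccc(Cl)cc3)cccc21)c1ccccc1`, 29500 nM
compound 2, `O=C(NC(=S)N1CCc2cc(OCc3ccccc3)ccc21)c1ccccc1`, 45200 nM
compound 3, `O=C(NC(=S)N1CCc2c(OCCCCCOc3ccc(Cl)cc3)cccc21)c1ccc(C(F)(F)F)cc1`, 32700 nM

Of the compounds shown here, three have been tested in an ADME assay on Huh-7 cells (Homo sapiens) for cytotoxicity; a lower number here means that less compound is tolerated, a higher number that more compound is tolerated. In this assay compound 1 gives 29500 nM, compound 2 gives 45200 nM, and compound 3 gives 32700 nM. Compound 3 stands within the scatter of both neighbours: its gap to compound 1 and its gap to compound 2 are each within the usual scatter, so the three numbers cannot be told apart. Going by the values given here, no step between compounds that differ in one place is available, and no pattern can be claimed from them.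

Compound 4, `O=C(NC(=S)N1CCc2c(OCCCCCOc3ccc(Cl)cc3)cccc21)c1cc2ccccc2s1`, has not yet been tested. It differs from compound 3 in one place: 1-benzothiophen-2-yl in place of 4-(trifluoromethyl)phenyl on a carbonyl carbon. This is 1-benzothiophen-2-yl in place of 4-(trifluoromethyl)phenyl on a carbonyl carbon whose other neighbours are an amide-type nitrogen.

Among the compounds with values here, with three values that all sit within the scatter of one another and no single-place step to lean on, a step of no size beyond the scatter is expected. The expected step is a 1.1-fold lower number from compound 3 to compound 4 (0.04 log units; within the scatter). Compound 4 is estimated at 30000 nM, with a range from 14000 nM to 65000 nM.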

Compound 4, half-maximal cytotoxic concentration: > 50000 nM
Compound 4 ended at the assay's limit; the forecaster's own chance of this, stated with the estimate: 15%; at least 1.6-fold (0.22 log units) between middle value and limit.
By their numbers in this assay, from the lowest: compounds 1, 3 and 2 (each within the scatter of the next). At a limit, above all of these: compound 4.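

Going by these compounds alone, this is the first comparison of two compounds that differ in one place in this assay: replacing 4-(trifluoromethyl)phenyl with 1-benzothiophen-2-yl on a carbonyl carbon gives an at least 1.5-fold higher number from compound 3 to compound 4 (0.18 log units; that floor lies within the scatter). In this assay compound 4 gives > 50000 nM, which is a limit of the assay and not a number. At this place, then, the exchange of a group with one aromatic ring for one with two did not lower the number, though the floor of the step does not clear the scatter and its real size stays unknown, with compound 4 standing at the limit: the limit of > 50000 nM in this assay, at which 1 of the 4 values shown sits.

The compounds shown leave open how far compound 4 lies past the limit, and whether any gain belongs to the five-membered ring holding sulfur or to the second ring as such. They also do not say what a pyridine ring or a carboxylic acid on the aromatic group would give at this carbonyl carbon, or whether the same exchange would hold on the core of compound 1.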